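Removing the fluoro from a weak antiproliferative amide

A few compounds are considered here, and "the series" means these few. Any claim that something is new, unique, unknown or untested is made for them only; others in the source may bear on it.

Measured compounds:
compound 1 `O=C(Nc1ccc(Cl)c(-c2nnc3c(Cl)cccn23)c1)c1ccccc1` 76900 nM
compound 2 `O=C(Nc1ccc(Cl)c(-c2nnc3c(Cl)cccn23)c1)c1c(F)cccc1Cl` 72300 nM

In a functional assay on A549 cells (Homo sapiens) for antiproliferative activity, read by MTT assay, with a stated time of 72 h (a higher number here means a weaker inhibitor, a lower number a stronger inhibitor), compound 2 gives 72300 nM, which sits within the scatter of the number for compound 1, so the two cannot be ordered. For the measured compounds named here, the one measured step, a 1.1-fold lower number from compound 1 to compound 2 (0.03 log units; within the scatter), shows that placing chloro and fluoro on the benzamide ring changed the readout by less than the usual scatter.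

Compound 3 `O=C(Nc1ccc(Cl)c(-c2nnc3c(Cl)cccn23)c1)c1ccccc1Cl` differs from compound 2 by hydrogen in place of fluoro on an aromatic carbon. Going by the values given here, the step from compound 1 to compound 2 is the only comparison that bears on this change, and since the combined entry of chloro and fluoro left the number within the scatter, the loss of the fluoro alone is expected to do the same in this assay. Compound 3 is therefore estimated at 75000 nM (range 35000 nM to 160000 nM), a step of a 1.0-fold higher number from compound 2 to compound 3 (0.02 log units; within the scatter) that is expected to lie within the scatter.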

Compound 3, half-maximal inhibitory concentration: > 100000 nM
Compound 3: no number, only a limit (the forecaster's own chance of this, stated with the estimate: 10%); at least 1.3-fold (0.12 log units) between middle value and limit.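

In this assay, the entry for compound 3 is a limit and not a number: the limit of > 100000 nM in this assay, at which 1 of the 3 values shown sits. Replacing the fluoro with hydrogen gives an at least 1.3-fold higher number from compound 2 to compound 3 (0.14 log units; that floor lies within the scatter), and adding only the chloro to the phenyl gives an at least 1.3-fold higher number from compound 1 to compound 3 (0.11 log units; that floor lies within the scatter). For the compounds shown here, these are floors, so the earlier compounds' closely matched numbers no longer settle the matter: the true size of each step is unknown, and the change from 2-chloro-6-fluorophenyl to 2-chlorophenyl may or may not exceed the scatter.

The compounds shown leave open whether an amine or a carboxylic acid in place of the fluoro would move the number beyond the scatter in either direction. They also leave open whether the fluoro alone, without the chloro, would do so.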